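The source may hold more compounds than are shown below. What is called first, only, known or untested is meant among the compounds shown, and "the series" means these compounds.

Three compounds have so far been measured in a functional assay on microsomes for inhibition, with a stated time of 1 h; on this read-out lower numbers stand for stronger inhibition and higher numbers for weaker inhibition:

Compound 1, `Cn1c(NN)nc(-c2ccco2)c(C#N)c1=O`: 78 ug/mL
Compound 2, `CCOC(=O)c1cnn(-c2nc(-c3ccc(OC)cc3)c(C#N)c(=O)n2C)c1N`: 68 ug/mL
Compound 3, `CN(C)c1ccc(-c2nc(NN)n(C)c(=O)c2C#N)cc1`: 63 ug/mL

Among these three numbers compound 2 gives the second highest, yet its distance to either neighbour is small: compound 3 lies within the scatter of compound 2, and so does compound 1. On this evidence the three measured compounds cannot be told apart in this assay, and none of them can be called stronger or weaker than another.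

The next compound to be measured is compound 4, `CCOC(=O)c1cnn(-c2nc(-c3ccco3)c(C#N)c(=O)n2C)c1N`. It differs from compound 2 in one place:

furan-2-yl in place of 4-methoxyphenyl on an aromatic carbon

Among the compounds with values here, a step of this kind has not been measured between any two compounds in the set, so there is no measured step to lean on. What can be said is that compound 1, which already carries furan-2-yl, and compound 3, which carries a six-membered aromatic ring at the same place, both give numbers within the scatter of compound 2 in this assay. From this the step from compound 2 to compound 4 is expected to stay within the scatter, in no particular direction: a 1.1-fold higher number from compound 2 to compound 4 (0.02 log units; within the scatter). Compound 4 is therefore estimated to give about 72 ug/mL in this assay, with a range from 45 ug/mL to 115 ug/mL.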

Compound 4, half-maximal inhibitory concentration: 116 ug/mL
Compound 4: middle estimate off by 1.6-fold (0.21 log units), on the low side, and the stated range ends below it.
By their numbers in this assay, from the lowest: compounds 3, 2, 1 and 4 (each within the scatter of the next).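

In this assay, the change at this place now has a measured size: exchanging 4-methoxyphenyl for furan-2-yl on the aromatic carbon ortho to a cyano group gives a 1.7-fold higher number from compound 2 to compound 4 (0.23 log units; within the scatter). The exchange replaces a six-membered aromatic ring of carbon only with a five-membered aromatic ring with one hetero atom, and takes the group from eight heavy atoms to five, yet with the ethyl ester and amino-bearing side of compound 2 and compound 4 held constant, the two numbers cannot be told apart. So, for this one pair, a clear difference in ring size and ring atoms at this place comes with no change that can be separated from ordinary repeat-to-repeat variation, and nothing measured here offers an explanation for the numbers.

A single pair cannot show whether the same holds with other parts of the molecule changed, so this reading stays confined to compound 2 and compound 4. Also open, on these data alone, is whether a carboxylic acid on the ring, a saturated ring such as cyclohexyl, or a longer alkyl chain in place of the aromatic ring would move the number beyond the scatter.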